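A few compounds are considered here, and "the series" means these few. Any claim that something is new, unique, unknown or untested is made for them only; others in the source may bear on it.

Of the compounds shown here, two have been tested in a functional assay on MT2 cells (Homo sapiens) for cytotoxicity, read by MTT assay; a higher number here means that more compound is tolerated, a lower number that less compound is tolerated. Compound 1 `CC(C)=CCOc1cc(Nc2nccs2)ccc1Cl` gives 26000 nM. Compound 2 `CC(C)=CCOc1cc(Nc2nccc(C)n2)ccc1Cl` gives < 200 nM, which is a limit of the assay rather than a number. Compound 2 thus stands at the limit of < 200 nM in this assay, at which 1 of the 2 values shown sits. For the measured compounds named here, the only measured step is an at least 130-fold lower number from compound 1 to compound 2 (2.11 log units; beyond the scatter), brought about by 4-methylpyrimidin-2-yl in place of 1,3-thiazol-2-yl on a nitrogen on an aromatic ring. Compound 3 `CSc1ccnc(Nc2ccc(Cl)c(OCC=C(C)C)c2)n1` keeps the core of compound 2 and differs only by methylsulfanyl in place of methyl on an aromatic carbon. Going by the values given here, no measured step touches an exchange of this kind, so no step beyond the usual scatter is expected, and the expected step that the limit leaves unreadable from compound 2 to compound 3 means about the same tolerance as seen for compound 2. Compound 3 is therefore estimated at 150 nM, with a range from 50 nM to 600 nM, and it may well again be reported only as a limit.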

Compound 3, half-maximal cytotoxic concentration: 2800 nM
The estimate for compound 3 lay 19-fold (1.27 log units) below the measured number, and the stated range ends below it.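

In this assay, methylsulfanyl in place of methyl on an aromatic carbon gives an at least 14-fold higher number from compound 2 to compound 3 (1.14 log units; beyond the scatter). So tolerance in this series depends not only on which ring sits on the nitrogen, as the earlier step showed, but also on a small group on that ring: the exchange adds just one sulfur atom to the substituent, yet the change is large. The step gives only a minimum, and its full size cannot be read, because the value of compound 2 is a limit and not a number: the limit of < 200 nM in this assay, at which 1 of the 3 values shown sits.

The compounds shown cannot separate the effect of the sulfur from that of the longer substituent, and an ethyl or a methoxy group at this place would bear on that question. As far as these compounds go, how an amine there would compare also remains open.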